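The source may report more compounds than this note shows. Statements on the series, on what has been measured and on what is new or still open speak of the compounds shown alone.

Measured so far in this assay:
- compound 1, `Cc1oc(-c2c(Cl)cccc2Br)nc1CN1CCC(C(=O)NCCCN2C[C@H](C)C[C@H](C)C2)CC1`: 0.0233 h
- compound 2, `Cc1ccccc1-c1nc(CN2CCC(C(=O)NCCN3C[C@H](C)C[C@H](C)C3)CC2)c(C)o1`: > 0.5 h, a limit of the assay

Among the measured compounds shown here, in an ADME assay on microsomes from liver (Rattus norvegicus) for metabolic stability, read by LC-MS, using NADPH, at 37 degrees C (a higher number here means that the compound lasts longer, a lower number that the compound disappears faster), compound 1 gives 0.0233 h, the only plain number in the set. Compound 2 is reported at > 0.5 h, which is a limit of the assay and not a number; this is the limit of > 0.5 h in this assay, at which 1 of the 2 values shown sits. Between compound 1 and compound 2 the two values show only that compound 1 disappears within the measured window and compound 2 does not, and no single-point step is available.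

The next compound, compound 3 `COc1cccc(C)c1-c1nc(CN2CCC(C(=O)NCCCN3C[C@H](C)C[C@H](C)C3)CC2)c(C)o1`, is still to be measured in this assay. It differs from compound 1 in one place: 2-methoxy-6-methylphenyl in place of 2-bromo-6-chlorophenyl on an aromatic carbon. For the measured compounds named here, no measured step of this kind exists, so the expectation rests on compound 1 alone and on compound 2 sitting at the limit with a methyl-bearing aryl group. The step from compound 1 to compound 3 is expected to be upward and beyond the scatter, an 8.6-fold higher number from compound 1 to compound 3 (0.93 log units; beyond the scatter). Compound 3 is estimated at 0.2 h, within a range of 0.05 h to 0.6 h.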

Compound 3, half-life: 0.0767 h
Beside the measured number, compound 3's estimate is 2.6-fold (0.42 log units) above it; low and high end bracket the measured number.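

In this assay, among the compounds shown here, 2-methoxy-6-methylphenyl in place of 2-bromo-6-chlorophenyl gives the first readable step at this position, on the aromatic carbon of the five-membered aromatic ring next to the ring nitrogen and next to the ring oxygen: a 3.3-fold higher number from compound 1 to compound 3 (0.52 log units; beyond the scatter). Both ends of this step are plain numbers and the rest of the molecule stays the same, so the aryl group at this position alone is enough to move the half-life in this assay beyond the usual scatter, with the number going up when the chlorine and bromine leave and the methoxy and methyl enter. The measurements shown tie this step to no cause.

Going by these compounds, the methoxy and the methyl enter together and the two halogens leave together, so how much of the step belongs to each group remains open, and a single exchange of one group at a time would be needed to separate them. Also open, on these data alone, is how this position responds to other groups on the phenyl ring, such as a nitrile, a trifluoromethyl or an amine.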